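The compounds below may be only part of what the source reports. "The series", "measured", "known", "first", "only" and "open" are said of these compounds alone.

Values in a functional assay on thoracic aorta (Rattus norvegicus, strain Wistar), with a stated time of 15 min (a higher number here means that more compound is needed for the effect, a lower number that less compound is needed), are as follows:
Compound 1 `CCOc1ccc(Cl)cc1C(C)NC(=O)NS(=O)(=O)c1ccc(C)cc1` gives > 300000 nM as a limit
Compound 2 `COc1ccc(OC)c(CNC(=O)NS(=O)(=O)c2ccc(Cl)cc2)c1` gives > 300000 nM as a limit
Compound 3 `COc1ccc(OC)c(CNC(=O)N(C)S(=O)(=O)c2ccc(Cl)cc2)c1` gives 18200 nM as the only number

Compound 4 `COc1ccc(OC)c(CNC(=O)N(C)S(=O)(=O)c2ccc(C)cc2)c1` differs from compound 3 at one place, with methyl in place of chloro on an aromatic carbon.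

Going by the values given here, the one measured step of an at least 16-fold lower number from compound 2 to compound 3 (1.21 log units; beyond the scatter) is large, but it is methyl in place of hydrogen on an amide-type nitrogen, and compound 4 keeps that methyl. Among the compounds with values here, no measured step covers the aromatic position, so no step beyond the scatter is expected in this assay. The expected step is a 1.1-fold higher number from compound 3 to compound 4 (0.04 log units; within the scatter) as an estimate. A reading at the limit of > 300000 nM in this assay, at which 2 of the 3 values shown sit, remains possible. The estimate for compound 4 is 20000 nM with an expected range from 7000 nM to 60000 nM overall.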

Compound 4, half-maximal effective concentration: 20900 nM
Compound 4: the middle estimate sits 1.0-fold (0.02 log units) below what was measured; measured number inside the range.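

Going from 4-chlorophenyl to 4-methylphenyl, with the methyl on the amide-type nitrogen kept, gives a 1.1-fold higher number from compound 3 to compound 4 (0.06 log units; within the scatter) in this assay, so chloro and methyl on this aromatic carbon cannot be told apart here. The step also shows that the number seen with the nitrogen methyl does not depend on chloro at this position. Compound 3 and compound 4 both read as numbers, clear of the limit: the limit of > 300000 nM in this assay, at which 2 of the 4 values shown sit.

Still open, as far as these compounds go, is how an amine, a carboxylic acid or a longer chain on this aromatic carbon would read. Also open, from the compounds shown here alone, is whether the nitrogen methyl step carries over to the 4-methylphenyl series.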